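The compounds below may be only part of what the source reports. "The series", "measured", "known", "first", "only" and "open" are said of these compounds alone.

Measured in a functional assay on MDA-MB-231 cells (Homo sapiens) for cytotoxicity, read by MTT assay, with a stated time of 72 h; on this read-out lower numbers stand for stronger inhibition and higher numbers for weaker inhibition:
Compound 1 `FC(F)(F)c1ccc(CSc2nc(N3CCCCC3)c3ccccc3n2)cc1` gives 28400 nM.
Compound 2 `COc1ccccc1Nc1nc(SCc2ccc(C(F)(F)F)cc2)nc2ccccc12` gives only a limit of the assay, > 50000 nM.
Compound 3 `FC(F)(F)c1ccc(CSc2nc(Nc3ccc(Cl)cc3)c3ccccc3n2)cc1` gives 15100 nM.

Compound 3 has the lowest of the two numbers given; its neighbour is compound 1, but the step of a 1.9-fold lower number from compound 1 to compound 3 (0.27 log units; within the scatter) stays within the scatter, so no order between them can be claimed. Compound 4 `CCOc1ccc(Nc2nc(SCc3ccc(C(F)(F)F)cc3)nc3ccccc23)cc1` differs from compound 3 by ethoxy in place of chloro on an aromatic carbon. Within the data shown here, the only measured step that touches this aryl group is an at least 3.3-fold lower number from compound 2 to compound 3 (0.51 log units; beyond the scatter), which changes both the group and its place and ends at a limit (the limit of > 50000 nM in this assay, at which 1 of the 3 values shown sits), so it gives little guidance. A modest rise in number is therefore expected, a 1.7-fold higher number from compound 3 to compound 4 (0.22 log units; within the scatter), and compound 4 is estimated at 25000 nM, between 10000 nM and 60000 nM.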

Compound 4, half-maximal inhibitory concentration: 23000 nM
Compound 4: the middle estimate sits 1.1-fold (0.04 log units) above what was measured; the range from low to high includes it.
By their numbers in this assay, from the lowest: compounds 3, 4 and 1 (each within the scatter of the next). At a limit, above all of these: compound 2.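

In this assay, ethoxy in place of chloro gives a 1.5-fold higher number from compound 3 to compound 4 (0.18 log units; within the scatter), and (4-ethoxyphenyl)amino in place of piperidin-1-yl gives a 1.2-fold lower number from compound 1 to compound 4 (0.09 log units; within the scatter), so neither change can be read as a real difference. Among these compounds, only one step with this new group passes the scatter: an at least 2.1-fold lower number from compound 2 to compound 4 (0.33 log units; beyond the scatter). Compound 2 gives a limit of the assay, not a number: the limit of > 50000 nM in this assay, at which 1 of the 4 values shown sits.

On these data alone, it remains open whether an amine or a carboxylic acid in place of ethoxy would shift the number beyond the scatter. Also open, as far as these compounds go, is what chloro or ethoxy would do elsewhere on the same ring.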